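The source may hold more compounds than are shown below. What is called first, only, known or untested is meant among the compounds shown, and "the series" means these compounds.

Three compounds share one core and differ only in the group on the aromatic carbon next to the ring nitrogen. Compound 1 `CC(C(=O)NCc1ccc(C(F)(F)F)nc1-c1ccccc1F)c1ccc(NS(C)(=O)=O)c(F)c1` carries a 2-fluorophenyl there and gives 63.3 nM in an assay on CHO cells for antagonist activity at transient receptor potential cation channel subfamily V member 1 (Homo sapiens), read by FLIPR; on this read-out lower numbers stand for stronger inhibition and higher numbers for weaker inhibition; compound 2 `CC(C(=O)NCc1ccc(C(F)(F)F)nc1Cc1ccccc1)c1ccc(NS(C)(=O)=O)c(F)c1` carries a benzyl and gives 141 nM; compound 3 `CC(C(=O)NCc1ccc(C(F)(F)F)nc1CCc1ccccc1)c1ccc(NS(C)(=O)=O)c(F)c1` carries a phenethyl and gives 1.4 nM, the lowest of the three numbers. The steps to it were large: a 45-fold lower number from compound 1 to compound 3 (1.66 log units; beyond the scatter) and a 100-fold lower number from compound 2 to compound 3 (2.00 log units; beyond the scatter), while a 2.2-fold higher number from compound 1 to compound 2 (0.35 log units; beyond the scatter).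

Compound 4 `CC(C(=O)NCc1ccc(C(F)(F)F)nc1C#Cc1ccccc1)c1ccc(NS(C)(=O)=O)c(F)c1` changes this group once more: 2-phenylethynyl in place of phenethyl on an aromatic carbon. The two groups match in their counts, and the difference lies in the chain that joins the ring to the core, where a triple bond takes the place of the saturated two-carbon chain. No measured step among these compounds involves a triple bond, so the direction can only be guessed. The steps into compound 3 show that the two-carbon spacer matters greatly, which suggests that altering it is more likely to cost than to gain. Compound 4 is therefore expected to give 10 nM in this assay, within a range of 1.5 nM to 70 nM, a step of a 7.1-fold higher number from compound 3 to compound 4 (0.85 log units; beyond the scatter).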

Compound 4, inhibition constant: 0.8 nM
For compound 4 the middle estimate is 13-fold (1.10 log units) above the measured one; measured number outside the range, below it.
By their numbers in this assay, from the lowest: compounds 4 and 3 (each within the scatter of the next); then compound 1; then compound 2.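

In this assay, 2-phenylethynyl in place of phenethyl gives a 1.8-fold lower number from compound 3 to compound 4 (0.24 log units; within the scatter), so the two groups cannot be told apart here, and a triple bond serves this position as well as the saturated two-carbon chain. The shape of the earlier pattern holds: 2-phenylethynyl stands well clear of benzyl, with a 180-fold lower number from compound 2 to compound 4 (2.25 log units; beyond the scatter), and of 2-fluorophenyl, with a 79-fold lower number from compound 1 to compound 4 (1.90 log units; beyond the scatter), so both groups with this two-carbon link sit far from the other two. Nothing available gives a reason why the two links match.

The compounds shown leave open how a longer chain, such as phenylpropyl, would read here, and whether the end phenyl ring could give way to a cyclohexyl ring. They also leave open whether a link containing an amine or an ether oxygen would keep the number this low.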